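Swapping cyclohexyl for cyclopropyl in compound 1

The source may report more compounds than this note shows. Statements on the series, on what has been measured and on what is new or still open speak of the compounds shown alone.

In a functional assay on SW1573 cells (Homo sapiens) for antiproliferative activity, read by sulforhodamine B assay, with a stated time of 48 h (on this read-out higher numbers stand for weaker inhibition of growth and lower numbers for stronger inhibition of growth), compound 1 (`COC(=O)C#CC(O/C=C/C(=O)OC)C1CCCCC1`) gives 2100 nM as its measured value. Two relatives sit at practically the same level: compound 2 (`COC(=O)C#CC(CCc1ccccc1)O/C=C/C(=O)OC`) gives 2600 nM and compound 3 (`CCOC(=O)C#CC(C[C@@H](C)CCC=C(C)C)O/C=C/C(=O)OCC`) gives 2600 nM in the same test. These gaps lie within the usual scatter of repeated measurements, so compound 1 cannot be ranked against either of them.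

The next molecule, compound 4 (`COC(=O)C#CC(O/C=C/C(=O)OC)C1CC1`), has not been measured yet. It carries cyclopropyl in place of cyclohexyl on a saturated chain carbon bound to an oxygen on an unsaturated carbon and a triple-bonded carbon and is otherwise the same as compound 1.

Among the measured compounds shown here, no two measured compounds here differ in one place only, so the size of such a swap in this assay has not been seen directly. For the measured compounds named here, the only guide is that compound 2 at 2600 nM and compound 3 at 2600 nM carry other groups at that carbon and still stay within the scatter of compound 1, which gives 2100 nM with its cyclohexyl. A slightly higher number, meaning slightly weaker inhibition of growth, is the most that is expected. The estimated step of a 1.4-fold higher number from compound 1 to compound 4 (0.15 log units; within the scatter) is expected to stay within the scatter. Compound 4 is expected at 3000 nM as the central estimate, with an estimated range of 1400 nM to 7000 nM on this measure.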

Compound 4, concentration for 50% growth inhibition: 1800 nM
The estimate for compound 4 lay 1.7-fold (0.22 log units) above the measured number; measured number inside the range.
By their numbers in this assay, from the lowest: compounds 4, 1, 2 and 3 (each within the scatter of the next).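

In this assay, among the compounds shown here, the change at the saturated chain carbon bound to an oxygen on an unsaturated carbon and a triple-bonded carbon gives a 1.2-fold lower number from compound 1 to compound 4 (0.07 log units; within the scatter), and this is the first direct reading of a single swap at this position. Replacing cyclohexyl, with 6 heavy atoms, by cyclopropyl, with 3 heavy atoms, therefore leaves the result indistinguishable from that of the parent, so these two carbon rings cannot be told apart in this test. Nothing available explains why they read alike.

For the compounds shown here, this single pair shows only that two saturated carbon rings give matching results, and it cannot establish a trend with ring size or show how far the position can be changed before growth inhibition shifts beyond the scatter. Still open, as far as these compounds go, is what happens at this carbon with a group of a different kind, such as a phenyl ring attached directly, a primary amine or a carboxylic acid, any of which could show whether this position responds to change at all.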